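A few compounds are considered here, and "the series" means these few. Any claim that something is new, unique, unknown or untested is made for them only; others in the source may bear on it.

Compound 1 `COc1ncnc2c1c(-c1cccs1)cn2[C@@H]1O[C@H](CO)[C@@H](O)[C@H]1O`, compound 2 `COc1ncnc2c1c(-c1ccccc1)cn2[C@@H]1O[C@H](CO)[C@@H](O)[C@H]1O` and compound 3 `CNc1ncnc2c1c(-c1ccccc1)cn2[C@@H]1O[C@H](CO)[C@@H](O)[C@H]1O` were tested in a functional assay on K562 cells (Homo sapiens), read by MTT assay, with a stated time of 72 h (a lower number here means a stronger inhibitor, a higher number a weaker inhibitor), while compound 4 `CNc1ncnc2c1c(-c1cccs1)cn2[C@@H]1O[C@H](CO)[C@@H](O)[C@H]1O` has not yet been measured there. In this assay compound 1 gives 6200 nM. Compound 2 reaches only a limit of the assay, > 20000 nM. Compound 3 likewise reaches only a limit of the assay, > 20000 nM. The change thiophen-2-yl in place of phenyl on an aromatic carbon produces an at least 3.2-fold lower number from compound 2 to compound 1 (0.50 log units; beyond the scatter). The cores of compound 2 and compound 3 differ by methylamino in place of methoxy on an aromatic carbon, and that step, a step that the two limits leave unreadable from compound 2 to compound 3, cannot be read because of the limit of > 20000 nM in this assay, at which 2 of the 3 values shown sit. The same change, (thiophen-2-yl in place of phenyl on an aromatic carbon), leads from compound 3 to compound 4. The step from compound 3 to compound 4 is expected to be an at least 2.5-fold lower number from compound 3 to compound 4 (0.39 log units; beyond the scatter), resting on the earlier at least 3.2-fold lower number from compound 2 to compound 1 (0.50 log units; beyond the scatter). Compound 4 is therefore estimated at 8000 nM, between 3000 nM and 30000 nM.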

Compound 4, half-maximal inhibitory concentration: > 20000 nM
Compound 4 ended at the assay's limit (the forecaster's own chance of this, stated with the estimate: 35%); at least 2.5-fold (0.39 log units) between middle value and limit.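

In this assay compound 4 gives > 20000 nM, which is a limit of the assay and not a number. Methylamino in place of methoxy on the core bearing thiophen-2-yl produces an at least 3.2-fold higher number from compound 1 to compound 4 (0.50 log units; beyond the scatter), so compound 4 does not keep the readable value of compound 1. Whether thiophen-2-yl in place of phenyl has any effect on the methylamino core is not shown, and the steps with a limit at both ends cannot be read because those compounds all sit at that limit: the limit of > 20000 nM in this assay, at which 3 of the 4 values shown sit.

The compounds shown leave open whether ethoxy or dimethylamino in place of methoxy would keep a readable value alongside thiophen-2-yl. They also leave open how furan-2-yl or thiophen-3-yl would behave on that aromatic carbon.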